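Aryl substitution on a spirocyclic thiophene core: a cyanophenyl step

This account rests on a few compounds, and the source may have more. Where it says the series, first, only, none or still open, it means among the compounds named here.

Values in an assay on membranes from brain for displacement of a labelled ligand from Sigma non-opioid intracellular receptor 1 (Cavia porcellus), read by scintillation counting, with a stated time of 120 min; a lower number here means a stronger inhibitor, a higher number a weaker inhibitor:
compound 1, `COc1ccc(-c2scc3c2CCOC32CCN(Cc3ccccc3)CC2)cc1`: 1.5 nM
compound 2, `COC1Cc2cscc2C2(CCN(Cc3ccccc3)CC2)O1`: 0.22 nM
compound 3, `COc1ccc(-c2scc3c2CC(OC)OC32CCN(Cc3ccccc3)CC2)cc1`: 2.2 nM

Compound 2 gives the lowest number of the three in this assay. Compound 1 stands nearest to it, and the two values show a clear gap; compound 3 stands furthest, and that gap is given as a 10-fold higher number from compound 2 to compound 3 (1.00 log units; beyond the scatter). The third measured step, a 1.5-fold higher number from compound 1 to compound 3 (0.17 log units; within the scatter), lies within the scatter.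

Compound 4, `COC1Cc2c(csc2-c2ccc(C#N)cc2)C2(CCN(Cc3ccccc3)CC2)O1`, is not yet measured. It differs from compound 2 by 4-cyanophenyl in place of hydrogen on an aromatic carbon. For the measured compounds named here, only one measured step bears on this change: the step of a 10-fold higher number from compound 2 to compound 3 (1.00 log units; beyond the scatter), in which an aryl group enters at the same aromatic carbon of the same core. That step was modest and went toward a higher number. Going by the values given here, compound 4 carries a different aryl group, a 4-cyanophenyl, and there is no measured pair that tells how it compares with 4-methoxyphenyl, so the expectation rests on the one aryl step alone and carries a wide range. The step expected from compound 2 to compound 4 in this assay is estimated as a 9.1-fold higher number from compound 2 to compound 4 (0.96 log units; beyond the scatter). Compound 4 is therefore expected to give about 2 nM, within 0.5 nM to 8 nM.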

Compound 4, inhibition constant: 0.25 nM
Compound 4: the middle estimate sits 8.0-fold (0.90 log units) above what was measured, outside the stated range (below it).
By their numbers in this assay, from the lowest: compounds 2 and 4 (each within the scatter of the next); then compounds 1 and 3 (each within the scatter of the next).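

In this assay, the aromatic carbon next to the ring sulfur takes a 4-cyanophenyl with a 1.1-fold higher number from compound 2 to compound 4 (0.06 log units; within the scatter), so an aryl group entering at this place on the shared core need not raise the number. The earlier 10-fold higher number from compound 2 to compound 3 (1.00 log units; beyond the scatter) therefore cannot be read as the effect of any aryl group at this carbon; it belongs to 4-methoxyphenyl, since an 8.8-fold lower number from compound 3 to compound 4 (0.94 log units; beyond the scatter), and that change of one group on the phenyl ring is beyond the scatter. Nothing given here accounts for why the two aryl groups part so clearly at this position.

The compounds shown leave open whether the flat result is peculiar to the nitrile, or whether other groups on the phenyl ring, such as an amine, a carboxylic acid or a fluorine, would stay with compound 4 or move toward compound 3. They also leave open whether the same exchange of cyano for methoxy would give a step of similar size on the core of compound 1, which lacks the methoxy on the saturated ring carbon.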